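One Sulfur Change, Repeated on a Second Core

The source may hold more compounds than are shown below. What is called first, only, known or untested is meant among the compounds shown, and "the series" means these compounds.

Of the compounds shown here, three have been tested so far in a functional assay on LNCaP cells (Homo sapiens) for antiproliferative activity, read by fluorescence and propidium iodide staining, with a stated time of 96 h; on this read-out lower numbers stand for stronger inhibition and higher numbers for weaker inhibition. Compound 1, with the structure `O=C(Nc1ccc(S(F)(F)(F)(F)F)cc1)c1ccc(Sc2ccc(O)cc2)cc1`, gives 4860 nM in this assay. Compound 2, with the structure `O=C(Nc1cccc(S(F)(F)(F)(F)F)c1)c1ccc(Sc2ccc(O)cc2)cc1`, is built from the same atoms joined differently; the difference between the two cores is not broken down here. In this assay compound 2 gives 3320 nM. Compound 3, with the structure `O=C(Nc1ccc(S(F)(F)(F)(F)F)cc1)c1ccc(S(=O)(=O)c2ccc(O)cc2)cc1`, gives 2490 nM in this assay.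

Compound 3 is obtained from compound 1 by one change: (4-hydroxyphenyl)sulfonyl in place of (4-hydroxyphenyl)sulfanyl on an aromatic carbon. That change made a step of a 2.0-fold lower number from compound 1 to compound 3 (0.29 log units; within the scatter).

Compound 4, with the structure `O=C(Nc1cccc(S(F)(F)(F)(F)F)c1)c1ccc(S(=O)(=O)c2ccc(O)cc2)cc1`, has not yet been measured. It stands to compound 2 as compound 3 stands to compound 1, through the change ((4-hydroxyphenyl)sulfonyl in place of (4-hydroxyphenyl)sulfanyl on an aromatic carbon). The place of the change is described in the same words in both pairs, so this is the same change, made on the core of compound 2 instead of the core of compound 1. This change has been seen once before among these compounds, and that single instance is the only guide available.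

From compound 2 to compound 4 a step of about a 1.8-fold lower number from compound 2 to compound 4 (0.27 log units; within the scatter) is expected, resting on the step from compound 1 to compound 3 of a 2.0-fold lower number from compound 1 to compound 3 (0.29 log units; within the scatter) and on the value of compound 2 of 3320 nM. Compound 4 is therefore estimated to give 1800 nM in this assay, with an expected range from 700 nM to 4500 nM.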

Compound 4, half-maximal inhibitory concentration: 3980 nM
The estimate for compound 4 lay 2.2-fold (0.34 log units) below the measured number; low and high end bracket the measured number.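

In this assay, putting (4-hydroxyphenyl)sulfonyl in place of (4-hydroxyphenyl)sulfanyl on the core of compound 2 gives a step of a 1.2-fold higher number from compound 2 to compound 4 (0.08 log units; within the scatter). Set beside the same change on the core of compound 1, the two steps cannot be told apart: the same change on two cores in this assay, a 2.0-fold lower number (0.29 log units; within the scatter) from compound 1 to compound 3 and a 1.2-fold higher number (0.08 log units; within the scatter) from compound 2 to compound 4, 2.3-fold (0.37 log units) apart, within the scatter of two such steps. This shows that, on both cores tested, the change leaves the number within the ordinary spread of repeated measurements, so nothing here marks one core as responding differently from the other; it does not show that the change has truly no effect, or that the two cores would behave alike for other changes, and two pairs are too few to establish a rule for the series.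

The compounds shown leave open whether a different link between the two aromatic rings, such as a sulfinyl group, an ether oxygen or a methylene, would give a step beyond the scatter. They also leave open what would follow if the hydroxyl group gave way to an amine or a carboxylic acid, or if the pentafluorosulfanyl group gave way to trifluoromethyl.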